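Nitro to Methoxycarbonyl on a Shared Amide Scaffold

This account rests on a few compounds, and the source may have more. Where it says the series, first, only, none or still open, it means among the compounds named here.

Three compounds share one core. In an assay on isolated protein for inhibition of Rho-associated protein kinase 1 (Homo sapiens), read by scintillation counting, radiometric assay and 33P incorporation, with a stated time of 40 min, in the presence of a further agent that is not named here (a higher number here means a weaker inhibitor, a lower number a stronger inhibitor), compound 1 `N#Cc1ccc(C(=O)Nc2cccc(NC(=O)COc3ccc4c(=O)ccoc4c3)c2)cc1` gives 123 nM, compound 2 `COc1ccc(C(=O)Nc2cccc(NC(=O)COc3ccc4c(=O)ccoc4c3)c2)cc1` gives 18 nM, and compound 3 `O=C(COc1ccc2c(=O)ccoc2c1)Nc1cccc(NC(=O)c2ccc([N+](=O)[O-])cc2)c1` gives 67 nM. Compound 3 stands second highest of the three: a 3.7-fold higher number from compound 2 to compound 3 (0.57 log units; beyond the scatter), whereas a 1.8-fold lower number from compound 1 to compound 3 (0.26 log units; within the scatter). Compound 4 `COC(=O)c1ccc(C(=O)Nc2cccc(NC(=O)COc3ccc4c(=O)ccoc4c3)c2)cc1` differs from compound 3 by methoxycarbonyl in place of nitro on an aromatic carbon. The measured steps that bear on this all swap the group on that ring: a 6.8-fold lower number from compound 1 to compound 2 (0.83 log units; beyond the scatter), a modest step, while the cyano-to-nitro change stayed within scatter. No measured step involves methoxycarbonyl, so its standing among these groups is unknown, and a step within the scatter is the most defensible expectation. Compound 4 is therefore expected at 60 nM in this assay, between 20 nM and 180 nM, which means a 1.1-fold lower number from compound 3 to compound 4 (0.05 log units; within the scatter).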

Compound 4, half-maximal inhibitory concentration: 72 nM
Compound 4: the middle estimate sits 1.2-fold (0.08 log units) below what was measured; the range from low to high includes it.
By their numbers in this assay, from the lowest: compound 2; then compounds 3, 4 and 1 (each within the scatter of the next).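

At this position, on the aromatic carbon para to a large group, methoxycarbonyl cannot be told apart from nitro (a 1.1-fold higher number from compound 3 to compound 4 (0.03 log units; within the scatter)) or from cyano (a 1.7-fold lower number from compound 1 to compound 4 (0.23 log units; within the scatter)). Methoxy alone stands apart from it (a 4.0-fold higher number from compound 2 to compound 4 (0.60 log units; beyond the scatter)), so compound 2 separates from compounds 1, 3 and 4, which form one group within the scatter. No accompanying measurement accounts for this separation.

As far as these compounds go, it remains open whether a longer ether such as ethoxy would stay with methoxy. An amine or a carboxylic acid at this position could fall with either side.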